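Isopropyl Amide to Hydroxamic Acid on a Shared Core

A few compounds are considered here, and "the series" means these few. Any claim that something is new, unique, unknown or untested is made for them only; others in the source may bear on it.

Compound 1 `O=C(O)/C=C/c1ccc(NCc2cccc(Oc3ccccc3)c2)cc1` and compound 2 `CC(C)NC(=O)[C@H]1C[C@@H]1c1ccc(NCc2cccc(Oc3ccccc3)c2)cc1` share one core. In a functional assay on CHO cells for agonist activity at Free fatty acid receptor 1 (Homo sapiens), read by a luciferase reporter (on this read-out lower numbers stand for smaller maximal responses and higher numbers for larger maximal responses), compound 1 gives 76% and compound 2 gives 62%, the lower of the two, and the step of a number 14 percentage points lower from compound 1 to compound 2 (beyond the scatter) was modest. Compound 3 `O=C(NO)[C@H]1C[C@@H]1c1ccc(NCc2cccc(Oc3ccccc3)c2)cc1` differs from compound 2 only by hydroxy in place of isopropyl on an amide-type nitrogen. For the measured compounds named here, no measured step touches this amide-type nitrogen, so the single known step offers no direct guide. For compound 3 the maximal response is therefore estimated at 68%, within 50% to 86%, an expected step of a number 6 percentage points higher from compound 2 to compound 3 (within the scatter) that may stay near the scatter.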

Compound 3, largest response reached (reported as percent of maximum), in percent of the reference or control that the assay uses: 90%
Compound 3: middle estimate off by 22 percentage points, on the low side, outside the stated range (above it).
By their numbers in this assay, from the lowest: compound 2; then compound 1; then compound 3.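

In this assay, the group on the amide-type nitrogen clearly matters: hydroxy in place of isopropyl gives a number 28 percentage points higher from compound 2 to compound 3 (beyond the scatter) with the rest of the molecule unchanged. The 2-(hydroxycarbamoyl)cyclopropyl group also goes past 2-carboxyethenyl, with a number 14 percentage points higher from compound 1 to compound 3 (beyond the scatter), whereas the 2-(isopropylcarbamoyl)cyclopropyl group fell short of it. Nothing measured here explains this rise. Still open, going by these compounds, is whether the hydroxy itself is needed, or whether a methoxy or an amino group on this nitrogen would serve as well. Also open, on these data alone, is how a carboxylic acid would fare on the cyclopropyl in place of the hydroxycarbamoyl.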